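Aryl amide variation on a shared aminopyrazine core

The source may hold more compounds than are shown below. What is called first, only, known or untested is meant among the compounds shown, and "the series" means these compounds.

Two compounds share a core and differ only in the group on the amide-type nitrogen. Compound 1 `Cc1noc(C)c1-c1cnc(N)c(Oc2ccc(C(=O)NC3CCCCC3)cc2)n1` carries cyclohexyl there, and in a functional assay on HepG2 cells (Homo sapiens) for inhibition, read by MTT assay, with a stated time of 72 h (on this read-out higher numbers stand for weaker inhibition and lower numbers for stronger inhibition), compound 1 gives 5420 nM. Compound 2 `Cc1noc(C)c1-c1cnc(N)c(Oc2ccc(C(=O)Nc3ccccc3)cc2)n1` carries phenyl there, and in this assay compound 2 gives 11800 nM. Among the compounds with values here, the step of a 2.2-fold higher number from compound 1 to compound 2 (0.34 log units; beyond the scatter) is the only measured comparison, and compound 2 therefore stands at the higher, weaker end of the two numbers.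

Compound 3 `Cc1noc(C)c1-c1cnc(N)c(Oc2ccc(C(=O)Nc3cccc(Cl)n3)cc2)n1` is not yet measured. It differs from compound 2 by 6-chloropyridin-2-yl in place of phenyl on an amide-type nitrogen. Within the data shown here, no measured step covers a swap of one aromatic ring for another on this nitrogen; the step from compound 1 to compound 2 concerns a saturated ring and does not bear on it directly. With nothing to guide the direction, the expected change a 1.2-fold lower number from compound 2 to compound 3 (0.07 log units; within the scatter) in this assay is no step beyond the scatter, and compound 3 is estimated at 10000 nM, within a range from 3500 nM to 30000 nM.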

Compound 3, half-maximal inhibitory concentration: 35700 nM
Compound 3: middle estimate off by 3.6-fold (0.55 log units), on the low side; measured number outside the range, above it.
By their numbers in this assay, from the lowest: compound 1; then compound 2; then compound 3.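

In this assay, exchanging one aromatic ring for another on the amide-type nitrogen clearly moves the result: putting 6-chloropyridin-2-yl in place of phenyl gives a 3.0-fold higher number from compound 2 to compound 3 (0.48 log units; beyond the scatter), so the number at this position depends on more than simply having an aromatic ring there. Replacing cyclohexyl with 6-chloropyridin-2-yl gives a 6.6-fold higher number from compound 1 to compound 3 (0.82 log units; beyond the scatter), and among these three compounds inhibition weakens in the order cyclohexyl, phenyl, 6-chloropyridin-2-yl. No measurement here explains why the number rises.

The ring nitrogen and the chlorine enter together, so the compounds shown cannot tell which of them matters, and a pyridin-2-yl group without chlorine would separate the two. Also open, as far as these compounds go, is how a small group such as methyl on this nitrogen would compare with these rings.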